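Methyl for amino on the aromatic ring of compound 1

The source may hold more compounds than are shown below. What is called first, only, known or untested is meant among the compounds shown, and "the series" means these compounds.

Compound 1 `CC1(C)CN(C2=CCCC2=O)c2cc(N)ccc2S1` carries an amino group on the fused six-membered aromatic ring. In a functional assay on aorta (Rattus norvegicus, strain Wistar) (a higher number here means a weaker inhibitor, a lower number a stronger inhibitor), compound 1 gives 3980 nM, the highest of the two numbers seen so far. For the measured compounds named here, the only other measured member, compound 2 `CC1CN(C2=CCCC2=O)c2cc(C(F)(F)F)ccc2S1`, gives 8.32 nM in this assay; compound 2 differs from compound 1 in more than one place, so no single step links them, and the two values simply show a wide gap between an amino-bearing and a trifluoromethyl-bearing member.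

Compound 3 `Cc1ccc2c(c1)N(C1=CCCC1=O)CC(C)(C)S2` is compound 1 after one change: methyl in place of amino on an aromatic carbon. Going by the values given here, no measured step of this kind exists in the set, so the expectation rests on the two values shown. A clear fall in the number is expected, with the step of a 100-fold lower number from compound 1 to compound 3 (2.00 log units; beyond the scatter) well beyond the scatter. Compound 3 is estimated at 40 nM in this assay, within 8 nM to 200 nM.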

Compound 3, half-maximal inhibitory concentration: 933 nM
Compound 3: the middle estimate sits 23-fold (1.37 log units) below what was measured, and the stated range ends below it.
By their numbers in this assay, from the lowest: compound 2; then compound 3; then compound 1.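

In this assay, this aromatic carbon now has its first single-place reading: a 4.3-fold lower number from compound 1 to compound 3 (0.63 log units; beyond the scatter), a step beyond the scatter but modest in size. Methyl in place of amino takes the count of hydrogen-bond donors and acceptors at this position to zero, yet the number stays far from that of the trifluoromethyl-bearing member, with compound 3 differing in more than one place from compound 2 at 8.32 nM. No measurement shown here accounts for the size of this step.

The compounds shown leave open how trifluoromethyl, a chlorine atom or a nitrile would read on this aromatic carbon with the rest of compound 3 held fixed. Also open, on these data alone, is what the extra methyl that compound 3 carries relative to compound 2 contributes on its own.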